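Methoxy added to the phenyl of compound 2

This account rests on a few compounds, and the source may have more. Where it says the series, first, only, none or still open, it means among the compounds named here.

Three compounds share one core. Compound 1 `O=C(O)c1ccc(/C=C2\SC(=S)N(c3ccccc3)C2=O)cc1` in an assay on isolated protein for inhibition of Apoptosis regulator Bcl-2 (Homo sapiens), read by fluorescence polarization (a lower number here means a stronger inhibitor, a higher number a weaker inhibitor), gives only a limit, > 10000 nM. Compound 3 `O=C(Nc1ccc(O)c(C(=O)O)c1)c1ccc(/C=C2\SC(=S)N(c3ccccc3)C2=O)cc1`, carrying (3-carboxy-4-hydroxyphenyl)amino in place of hydroxy on a carbonyl carbon, likewise gives only a limit in this assay, > 10000 nM. The step that the two limits leave unreadable from compound 1 to compound 3 is therefore unreadable. Compound 2 `O=C(O)c1ccc(COc2cccc(/C=C3\SC(=S)N(c4ccccc4)C3=O)c2)cc1` in this assay also returns only a limit, > 10000 nM. Its place among the numbers rests solely on (the limit of > 10000 nM in this assay, at which 3 of the 3 values shown sit). Compound 4 `COc1ccccc1N1C(=O)/C(=C/c2cccc(OCc3ccc(C(=O)O)cc3)c2)SC1=S` differs from compound 2 by methoxy in place of hydrogen on an aromatic carbon. No measured step bears on this change, and the single step shown cannot be sized, so no shift beyond the scatter is expected. The expected step is a step that the limit leaves unreadable from compound 2 to compound 4. Compound 4 is estimated at 20000 nM, within 6000 nM to 80000 nM.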

Compound 4, inhibition constant: 1600 nM
Beside the measured number, compound 4's estimate is 13-fold (1.10 log units) above it, outside the stated range (below it).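

Methoxy in place of hydrogen on an aromatic carbon, ortho to a large group, gives an at least 6.2-fold lower number from compound 2 to compound 4 (0.79 log units; beyond the scatter) in this assay and is the first readable step in the series. This phenyl is therefore a place where one small group moves the reading, which compound 1, compound 2 and compound 3 could not show, as all three give only limits.

As far as these compounds go, whether ethoxy, fluoro or an amine on the same phenyl carbon would match methoxy stays open. The full size of the step also stays open: the limit of > 10000 nM in this assay, at which 3 of the 4 values shown sit.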